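Removing one methyl from the amine of compound 1

The source may hold more compounds than are shown below. What is called first, only, known or untested is meant among the compounds shown, and "the series" means these compounds.

Among the measured compounds shown here, in a functional assay (brain) for inhibition, with Rattus norvegicus as the target (a higher number here means a weaker inhibitor, a lower number a stronger inhibitor), compound 1 (`CN(C)CC/C=C(\c1ccc(Br)cc1)c1cccnc1`) gives 1400 nM, the lower of the two numbers measured so far. Its double-bond partner, compound 2 (`CN(C)CC/C=C(/c1ccc(Br)cc1)c1cccnc1`), gives 22500 nM. For the measured compounds named here, the only measured step is large, a 16-fold higher number from compound 1 to compound 2 (1.21 log units; beyond the scatter), and it is due to the fact that compounds 1 and 2 differ only in the configuration as drawn.

Compound 3 (`CNCC/C=C(\c1ccc(Br)cc1)c1cccnc1`) keeps the double bond of compound 1 as drawn and changes the amine instead, with hydrogen in place of methyl on an amine nitrogen. Dimethylamino thus becomes methylamino. The measured step bears on this change only indirectly. Compound 3 shares the configuration of compound 1, so a loss on the scale of a 16-fold higher number from compound 1 to compound 2 (1.21 log units; beyond the scatter) is not expected. Going by the values given here, no measured pair tests the removal of a methyl from this amine, so the expectation rests on the small size of the change and remains uncertain in direction. A modest move toward a lower number is expected, a 2.3-fold lower number from compound 1 to compound 3 (0.37 log units; beyond the scatter). For compound 3 the estimated value is 600 nM, with an expected range from 170 nM to 2500 nM.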

Compound 3, half-maximal inhibitory concentration: 1000 nM
Compound 3: middle estimate off by 1.7-fold (0.22 log units), on the low side, and the stated range covers the measured number.
By their numbers in this assay, from the lowest: compounds 3 and 1 (each within the scatter of the next); then compound 2.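

In this assay, hydrogen in place of methyl on an amine nitrogen gives a 1.4-fold lower number from compound 1 to compound 3 (0.15 log units; within the scatter), so with the double bond as drawn in compound 1, dimethylamino and methylamino cannot be told apart at this position. Among the compounds shown here, the only earlier step, a 16-fold higher number from compound 1 to compound 2 (1.21 log units; beyond the scatter), concerned the configuration of the double bond and said nothing about the amine; this new step shows that, for this pair, one methyl on the amine nitrogen can be exchanged for hydrogen without a change beyond the scatter, in contrast to the large step seen for the configuration. Nothing given here offers an explanation for this result.

Going by these compounds, what stays open is how far the amine can be changed before the number moves: a primary amine, with hydrogen in place of both methyls, a pyrrolidine, or a longer chain carrying the amine could each behave differently from methylamino. On these data alone, it also remains open whether methylamino would match dimethylamino with the double bond as drawn in compound 2, where the number is much higher.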